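The compounds below may be only part of what the source reports. "The series", "measured", "known", "first", "only" and "open" are said of these compounds alone.

Compound 1 `O=C(NCc1ccc(CNS(=O)(=O)c2ccccc2)cc1)c1ccc([N+](=O)[O-])cc1`: 100 nM
Compound 2 `O=C(NCc1ccc(CNS(=O)(=O)c2ccccc2)cc1)c1ccccc1`: 1 nM
Compound 3 `O=C(NCc1ccc(CNS(=O)(=O)c2ccccc2)cc1)c1ccccc1Cl`: 10 nM

Of the compounds shown here, three sharing one core have been measured in an assay on MDA-MB-231 cells for binding affinity to C-X-C chemokine receptor type 4 (Homo sapiens), read by immunofluorescence and microscopy, with stated times of 10 min and 30 min; a higher number here means that more compound is needed for the effect, a lower number that less compound is needed. Compound 3 stands second highest of the three numbers: compound 1 is its nearest neighbour, a 10-fold lower number from compound 1 to compound 3 (1.00 log units; beyond the scatter), while compound 2 sits furthest from it, a 10-fold higher number from compound 2 to compound 3 (1.00 log units; beyond the scatter). The largest movement in the set is a 100-fold lower number from compound 1 to compound 2 (2.00 log units; beyond the scatter), which comes from hydrogen in place of nitro on an aromatic carbon.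

Compound 4 `O=C(NCc1ccc(CNS(=O)(=O)c2ccccc2)cc1)c1ccc(Cl)cc1` has not yet been measured. It differs from compound 3 in one place: 4-chlorophenyl in place of 2-chlorophenyl on a carbonyl carbon. Within the data shown here, no measured step moves a chloro group in this way, so the bearing steps are indirect. The step of a 10-fold higher number from compound 2 to compound 3 (1.00 log units; beyond the scatter) shows that a chloro on the 2-chlorophenyl cost a modest amount against the bare phenyl of compound 2, and a 100-fold lower number from compound 1 to compound 2 (2.00 log units; beyond the scatter) shows that a substituent on the 4-nitrophenyl of compound 1 cost far more. Taken together, a 4-chlorophenyl is expected to sit at or somewhat above compound 3, with no confident direction beyond the scatter. The expected step is a 2.0-fold higher number from compound 3 to compound 4 (0.30 log units; within the scatter), so compound 4 is estimated at 20 nM, with a range from 5 nM to 100 nM.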

Compound 4, effective concentration (reported as EC, without a stated level of effect): 100 nM
Compound 4: the middle estimate sits 5.0-fold (0.70 log units) below what was measured; the range from low to high includes it.
By their numbers in this assay, from the lowest: compound 2; then compound 3; then compounds 1 and 4 (each within the scatter of the next).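

Moving the chloro is not a neutral change in this assay: the 2-chlorophenyl and the 4-chlorophenyl have the same atoms, yet the exchange on the carbonyl carbon gives a 10-fold higher number from compound 3 to compound 4 (1.00 log units; beyond the scatter) and shows that the place of the chloro matters, not only its presence. Against the bare phenyl, the 4-chlorophenyl gives a 100-fold higher number from compound 2 to compound 4 (2.00 log units; beyond the scatter) in this assay, a large step that sets compound 4 well apart from the best compound shown. Exchanging the nitro of the 4-nitrophenyl for chloro gives no change at the digits printed from compound 1 to compound 4 (within the scatter) and so leaves the number unmoved, which means these two groups cannot be told apart in this assay, while no evidence is available to explain the result.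

From the compounds shown here alone, what remains open is whether a 4-methoxyphenyl, a 4-methylphenyl or a 4-fluorophenyl on the carbonyl carbon would match compound 4 or come closer to compound 2. Going by these compounds, it is also open whether a 2-fluorophenyl or a 2-methylphenyl would hold the number of compound 3, or whether an amine or a carboxylic acid on that ring would be tolerated at all.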